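The source may report more compounds than this note shows. Statements on the series, on what has been measured and on what is new or still open speak of the compounds shown alone.

Two compounds share a core and differ only in the group on the aromatic nitrogen. Compound 1 `CNC(=O)c1cc(Oc2ccc(NC(=O)c3cc4cccnc4n(-c4ccc(Cl)cc4)c3=O)cc2)ccn1` gives 370 nM in a functional assay on A549 cells (Homo sapiens) for antiproliferative activity, read by MTT assay, with a stated time of 72 h; a higher number here means a weaker inhibitor, a lower number a stronger inhibitor. For the measured compounds named here, compound 2 `CNC(=O)c1cc(Oc2ccc(NC(=O)c3cc4cccnc4n(-c4ccc(Br)cc4)c3=O)cc2)ccn1` gives 1050 nM in this assay, the higher of the two numbers; the only measured step, a 2.8-fold higher number from compound 1 to compound 2 (0.45 log units; beyond the scatter), is modest but beyond the scatter. Compound 3 `CNC(=O)c1cc(Oc2ccc(NC(=O)c3cc4cccnc4n(-c4ccc(C(F)(F)F)cc4Cl)c3=O)cc2)ccn1` has not been measured. It differs from compound 2 by 2-chloro-4-(trifluoromethyl)phenyl in place of 4-bromophenyl on an aromatic nitrogen. Going by the values given here, no measured step covers this exact change; the only step that touches the same position is a 2.8-fold higher number from compound 1 to compound 2 (0.45 log units; beyond the scatter), which shows that the group on this nitrogen can shift the number by a modest amount in either direction. He therefore expects a step of a 1.6-fold lower number from compound 2 to compound 3 (0.21 log units; within the scatter) for compound 3, with the direction uncertain. His estimate for compound 3 in this assay is 650 nM, within a range from 150 nM to 2800 nM.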

Compound 3, half-maximal inhibitory concentration: 2090 nM
Compound 3: middle estimate off by 3.2-fold (0.51 log units), on the low side, within the range that was stated.
By their numbers in this assay, from the lowest: compound 1; then compounds 2 and 3 (each within the scatter of the next).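

In this assay, putting 2-chloro-4-(trifluoromethyl)phenyl in place of 4-bromophenyl on the aromatic nitrogen gives a 2.0-fold higher number from compound 2 to compound 3 (0.30 log units; within the scatter), so this change does not separate the two compounds. Measured against 4-chlorophenyl, the same group gives a 5.6-fold higher number from compound 1 to compound 3 (0.75 log units; beyond the scatter), which shows that a second, more heavily substituted phenyl group at this position also fails to match the number of compound 1, whose steps to both others lie beyond the scatter. Nothing available here accounts for these differences.

Going by these compounds, what the 2-chloro and the 4-(trifluoromethyl) parts each contribute stays open: compound 3 carries both at once. Also open, on these data alone, is how the number would respond to a phenyl ring bearing an amine or a methoxy group, or to a cyclohexyl group on this nitrogen.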